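Replacing the Aryl Group on Silicon with Cyclohexyl

The source may report more compounds than this note shows. Statements on the series, on what has been measured and on what is new or still open speak of the compounds shown alone.

Of the compounds shown here, three sharing one core have been measured in a functional assay on liver (Sus scrofa) for inhibition of squalene monooxygenase (Homo sapiens), using microsomes; on this read-out higher numbers stand for weaker inhibition and lower numbers for stronger inhibition. Compound 1 `CCN(C/C=C/C#CC(C)(C)C)Cc1cccc(OC[Si](C)(C)c2ccccc2C)c1` gives 30 nM. Compound 2 `CCN(C/C=C/C#CC(C)(C)C)Cc1cccc(OC[Si](C)(C)c2ccc(C=O)cc2)c1` gives 100 nM. Compound 3 `CCN(C/C=C/C#CC(C)(C)C)Cc1cccc(OC[Si](C)(C)c2ccc(S)cc2)c1` gives 8000 nM, the highest of the three numbers, and both of its steps from the others lie beyond the scatter: a 270-fold higher number from compound 1 to compound 3 (2.43 log units; beyond the scatter) and an 80-fold higher number from compound 2 to compound 3 (1.90 log units; beyond the scatter). On these numbers compound 3 is therefore the weakest inhibitor of the three.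

Compound 4 `CCN(C/C=C/C#CC(C)(C)C)Cc1cccc(OC[Si](C)(C)C2CCCCC2)c1` has not yet been measured. It differs from compound 3 in one place: cyclohexyl in place of 4-sulfanylphenyl on a silicon. The group attached to the silicon thus changes from an aromatic ring to a non-aromatic one.

For the measured compounds named here, no measured step involves cyclohexyl, so the outcome cannot be read directly from the data. What the data do show is that swapping the group on the silicon moves the number strongly: a 270-fold higher number from compound 1 to compound 3 (2.43 log units; beyond the scatter) and an 80-fold higher number from compound 2 to compound 3 (1.90 log units; beyond the scatter), with the smaller change a 3.3-fold higher number from compound 1 to compound 2 (0.52 log units; beyond the scatter) also beyond the scatter. Compound 3 stands apart from compounds 1 and 2, so a return toward their range is the more likely direction for compound 4.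

In this assay, compound 4 is expected to give about 150 nM, within a range from 30 nM to 1500 nM. This estimate means a step of a 53-fold lower number from compound 3 to compound 4 (1.73 log units; beyond the scatter), toward stronger inhibition, though the wide range reflects the absence of any measured cyclohexyl analogue.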

Compound 4, half-maximal inhibitory concentration: 20000 nM
For compound 4 the middle estimate is 130-fold (2.12 log units) below the measured one; the whole stated range lies below it.
By their numbers in this assay, from the lowest: compound 1; then compound 2; then compound 3; then compound 4.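

In this assay the change to cyclohexyl moves the number up, not down, with a 2.5-fold higher number from compound 3 to compound 4 (0.40 log units; beyond the scatter), which makes compound 4 the weakest inhibitor of the four and shows that replacing this aromatic ring with a non-aromatic one does not bring the number back toward compounds 1 and 2. The gaps to those two are large, with a 200-fold higher number from compound 2 to compound 4 (2.30 log units; beyond the scatter) and a 670-fold higher number from compound 1 to compound 4 (2.82 log units; beyond the scatter), so the one non-aromatic ring shown on the silicon sits at the weak end of the series, although compound 3 goes against any simple rule that an aromatic ring here is enough, as it keeps one and is also far weaker than compounds 1 and 2. Nothing measured here explains why cyclohexyl gives this result.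

Going by these compounds, it remains open whether the weak result belongs to cyclohexyl alone or extends to other saturated groups on the silicon, such as cyclopentyl or tert-butyl. A plain phenyl group would also be needed to show how the substituents on the aromatic ring in compounds 1, 2 and 3 compare with an unsubstituted ring.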